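Three Inactive Analogues and a Fourth at the Same Limit

The compounds below may be only part of what the source reports. "The series", "measured", "known", "first", "only" and "open" are said of these compounds alone.

Compound 1 is `Cc1nnc(SCC(=O)c2ccc(Cl)cc2)n1N1C(=O)c2ccccc2C1=O`. In a functional assay on HepG2 cells (Homo sapiens) for cytotoxicity, read by MTT assay, with a stated time of 48 h (a lower number here means a stronger inhibitor, a higher number a weaker inhibitor), compound 1 reaches only the assay limit of > 200000 nM, a limit and not a number. Compound 2 is `C=CCSc1nnc(-c2cc(OC)c(OC)c(OC)c2)n1N1C(=O)c2ccccc2C1=O`. In this assay compound 2 likewise stops at the limit > 200000 nM. Compound 3 is `COc1cc(-c2nnc(SCc3ccccc3Cl)n2N2C(=O)c3ccccc3C2=O)cc(OC)c1OC`. In this assay compound 3 again shows only the limit > 200000 nM.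

Compound 3 therefore stands at the same limit as the other two compounds shown; no number separates it from either. Among the measured compounds shown here, the single step between measured compounds that differ in one place, a step that the two limits leave unreadable from compound 2 to compound 3, cannot be read, since both of its ends are limits. Compound 4 is `COc1cc(-c2nnc(SCC(=O)c3ccc(Cl)cc3)n2N2C(=O)c3ccccc3C2=O)cc(OC)c1OC`. It differs from compound 3 by (4-chlorophenyl)carbonyl in place of 2-chlorophenyl on a saturated chain carbon bound to a sulfur. For the measured compounds named here, no measured step bears directly on this change; the only guidance is the limit of > 200000 nM in this assay, at which 3 of the 3 values shown sit, and the entering group is also present in compound 1, which sits at that same limit. The step from compound 3 to compound 4 is thus expected to show no readable change, a number no higher from compound 3 to compound 4 (the limit leaves the size open). Compound 4 is expected to remain at the limit, with an estimate of 200000 nM and a range from 100000 nM to 500000 nM.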

Compound 4, half-maximal inhibitory concentration: 22000 nM
Compound 4: the middle estimate sits 9.1-fold (0.96 log units) above what was measured; the whole stated range lies above it.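

In this assay, the group on the saturated chain carbon bound to a sulfur now makes a readable difference: (4-chlorophenyl)carbonyl in place of 2-chlorophenyl gives an at least 9.0-fold lower number from compound 3 to compound 4 (0.95 log units; beyond the scatter), and in place of vinyl it gives an at least 9.0-fold lower number from compound 2 to compound 4 (0.95 log units; beyond the scatter). That group is not enough alone, since 3,4,5-trimethoxyphenyl in place of methyl on an aromatic carbon gives an at least 9.0-fold lower number from compound 1 to compound 4 (0.95 log units; beyond the scatter), so among these compounds a number appears only where both groups are present. Compound 4 is the only compound shown to give a number rather than a limit: the limit of > 200000 nM in this assay, at which 3 of the 4 values shown sit.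

From the compounds shown here alone, the step from compound 2 to compound 3 cannot be read, and each new step starts from a limit, so its full size stays open. Also open, going by these compounds, is which part of the entering group goes with the step, and whether a 4-chlorobenzyl or a plain phenylcarbonyl at this place would give a number.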